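Compound 2 to compound 4: chloro to methyl

This account rests on a few compounds, and the source may have more. Where it says the series, first, only, none or still open, it means among the compounds named here.

compound 1 `O=C(CSc1ncnc2c1cnn2-c1ccccc1Cl)Nc1ncccn1` gives 2.2
compound 2 `COCCC(Oc1ncnc2c1cnn2-c1ccccc1Cl)C(=O)Nc1ccc(C)cn1` gives 4.1
compound 3 `COCC[C@H](Oc1ncnc2c1cnn2-c1ccccc1Cl)C(=O)Nc1ccc(C)cn1` gives 3.9

These three values come from a physicochemical assay for lipophilicity, read by HPLC, measured as octanol-water partition; a lower number here means a more polar compound, a higher number a more lipophilic compound. Compound 2 stands at 4.1, within the scatter of compound 3 at 3.9, while compound 1 lies well apart from both at 2.2.

The next structure is compound 4 `COCCC(Oc1ncnc2c1cnn2-c1ccccc1C)C(=O)Nc1ccc(C)cn1`. Its difference from compound 2 is methyl in place of chloro on an aromatic carbon, ortho to a large group.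

Among the compounds with values here, no measured step touches this place. Within the data shown here, the only one available is a number 0.20 log units lower from compound 2 to compound 3 (within the scatter), and it goes with the fact that one of compounds 2 and 3 is drawn with a defined configuration and the other without, at the place where they differ. That step concerns a stereocentre at a saturated chain carbon, so it gives no size for the present exchange. Among the measured compounds shown here, it does show that two closely related compounds read alike in this assay, and this is the only guide to how far a single local change moves the number here.

The expectation therefore stays close to compound 2 at 4.1, with no shift beyond the scatter in either direction. The expected change is a number 0.10 log units lower from compound 2 to compound 4 (within the scatter), and that estimate is deliberately small. For compound 4 the expected value is 4, with an estimated range from 3.6 to 4.4.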

Compound 4, distribution coefficient: 4.2
Beside the measured number, compound 4's estimate is 0.20 log units below it, and the stated range covers the measured number.
By their numbers in this assay, from the lowest: compound 1; then compounds 3, 2 and 4 (each within the scatter of the next).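

The exchange of 2-chlorophenyl to 2-methylphenyl is the only measured step at this position among the compounds shown, and in this assay it reads as a number 0.10 log units higher from compound 2 to compound 4 (within the scatter), so the series now has a direct reading for this place rather than one borrowed from a stereo step on the saturated chain. At this position, on an aromatic carbon of a six-membered aromatic ring of carbon only, ortho to a large group, one heavy atom is exchanged for one heavy atom, with no hydrogen-bond donor or acceptor on either side, and compound 2 and compound 4 cannot be told apart by this assay. Nothing on record bears on why chloro and methyl read alike here.

The compounds shown leave open how this assay responds at this position to a group of a different kind, such as a carboxylic acid, an amine or a methoxy group, or to a longer chain. They also leave open whether methyl in place of chloro reads the same way on the defined configuration drawn in compound 3.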